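A Charged Oxime with a Nitro-Bearing Side Chain

The source may report more compounds than this note shows. Statements on the series, on what has been measured and on what is new or still open speak of the compounds shown alone.

Within the data shown here, compound 1 `COCCOCn1cc[n+](C)c1/C=N/O` is one of two compounds measured in a physicochemical assay for lipophilicity (on this read-out higher numbers stand for higher lipophilicity and lower numbers for lower lipophilicity), and it is the only one of the pair with an actual number: in this assay compound 1 gives -2.81. Compound 2 `C[n+]1ccn(CCCC#N)c1/C=N/O` sits at a limit of the assay, which reports < -3 for compound 2 rather than a number. Among the measured compounds shown here, the one measured step, a number at least 0.19 log units lower from compound 1 to compound 2 (that floor lies within the scatter), is therefore known only by its floor, and that floor lies within the scatter of the assay (the limit of < -3 in this assay, at which 1 of the 2 values shown sits).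

Compound 3 `C[n+]1ccn(COCC(C)(C)[N+](=O)[O-])c1/C=N/O` differs from compound 1 in a single place: 1-methyl-1-nitroethyl in place of methoxymethyl on a saturated chain carbon bound to an oxygen on a saturated carbon. For the measured compounds named here, no measured step tests this exact exchange, since the step from compound 1 to compound 2 alters a different part of the chain, on the carbon bound to the aromatic nitrogen. Going by the values given here, what the data offer is only that one chain change moved the read-out by a small amount, and a comparably small step is expected here, with no clear direction. Compound 3 is therefore estimated at -2.8, between -3.3 and -2.3, an expected step of a number 0.01 log units higher from compound 1 to compound 3 (within the scatter).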

Compound 3, distribution coefficient: -1.96
Beside the measured number, compound 3's estimate is 0.84 log units below it; measured number above the stated range.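

This result shows that the saturated chain carbon bound to an oxygen on a saturated carbon is a place where a change in the side chain can clearly move the read-out in this assay: the exchange of methoxymethyl for 1-methyl-1-nitroethyl gives a number 0.85 log units higher from compound 1 to compound 3 (beyond the scatter). The entering group brings 6 heavy atoms against 3 and 2 hydrogen-bond acceptors against 1, so the higher number arrives together with both of these differences, and the exchange cannot separate them. The earlier compounds shown here could not show a step of readable size, since compound 2 rests on a limit of the assay and its step is known only by a floor within the scatter: the limit of < -3 in this assay, at which 1 of the 3 values shown sits.

Going by these compounds, it remains open whether the higher number belongs to the nitro group or to the branched carbon that carries it, and a tert-butyl group at the same place would be the direct comparison. Also open, on these data alone, is how an amine, a carboxylic acid or a longer chain at this place would read out, and whether the same exchange would give a similar step on a different side chain.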